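From 4-bromophenyl to 2,5-difluorophenyl: a small expected step

The compounds below may be only part of what the source reports. "The series", "measured", "known", "first", "only" and "open" are said of these compounds alone.

In a functional assay on MCF7 cells (Homo sapiens) for cytotoxicity, read by MTT assay, with a stated time of 96 h (on this read-out lower numbers stand for stronger inhibition and higher numbers for weaker inhibition), compound 3 (`COc1cc(C(=O)c2cn(-c3ccccc3)cc2-c2ccc(Br)cc2)cc(OC)c1OC`) gives 340 nM. That puts it in the middle of the three measured compounds: compound 2 (`COc1ccccc1-n1cc(C(=O)c2cc(OC)c(OC)c(OC)c2)c(-c2ccccc2)c1`) gives a lower number, 150 nM, and compound 1 (`COc1cc(C(=O)c2cn(-c3ccccc3N)cc2-c2ccccc2)cc(OC)c1OC`) gives a higher one, 3800 nM.

The next compound to be tested, compound 4 (`COc1cc(C(=O)c2cn(-c3ccccc3)cc2-c2cc(F)ccc2F)cc(OC)c1OC`), differs from compound 3 in a single group: 2,5-difluorophenyl in place of 4-bromophenyl on an aromatic carbon of a five-membered aromatic ring with 1 nitrogen, (2,5-difluorophenyl in place of 4-bromophenyl on an aromatic carbon).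

Going by the values given here, only one measured step links compounds that differ in one place, a 25-fold lower number from compound 1 to compound 2 (1.40 log units; beyond the scatter), with methoxy in place of amino on an aromatic carbon. It concerns other groups, so it gives no direct guide to the size or direction of the new step. It does show, through that same a 25-fold lower number from compound 1 to compound 2 (1.40 log units; beyond the scatter), that one swap in this small set can move the number a long way, so the range here is kept wide. Among the compounds with values here, with no measured step favouring either direction, no step beyond the scatter is expected in this assay. The estimated step is a 1.2-fold higher number from compound 3 to compound 4 (0.07 log units; within the scatter). For compound 4 the expected value is 400 nM, with an estimated range from 130 nM to 1200 nM.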

Compound 4, half-maximal inhibitory concentration: 230 nM
For compound 4 the middle estimate is 1.7-fold (0.24 log units) above the measured one; low and high end bracket the measured number.
By their numbers in this assay, from the lowest: compounds 2, 4 and 3 (each within the scatter of the next, the first and the last beyond it); then compound 1.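

Going by these compounds alone, at this place on the shared core, this assay gives a first reading of how much the attached ring can change, and the earlier compounds offered none. Exchanging 4-bromophenyl for 2,5-difluorophenyl gives a 1.5-fold lower number from compound 3 to compound 4 (0.17 log units; within the scatter), so the two numbers cannot be told apart, even though the bromine is gone and two fluorines sit at other places on the ring. At least for this pair, the exact halogen and its place on the phenyl ring can differ without a measurable change in this cell assay, although a single pair cannot establish a general rule. No measured property here accounts for this result.

Both groups are six-membered carbon rings carrying only halogens, with no hydrogen-bond donors or acceptors, so this pair says nothing about a phenyl ring bearing a carboxylic acid or a dimethylamino group, or about a morpholine ring at this place. Going by these compounds, it also remains open whether the same exchange would give so small a step on the core of compound 2, which carries a methoxy group on its other phenyl ring.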